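From chloro to isopropyl: an expected gain in potency

The compounds below may be only part of what the source reports. "The series", "measured", "known", "first", "only" and "open" are said of these compounds alone.

Going by the values given here, the three compounds measured so far share one core and differ only in the group on the aromatic ring. In a functional assay on a subcellular fraction from brain (Rattus norvegicus) for inhibition, read by scintillation counting, with a stated time of 5 min (a higher number here means a weaker inhibitor, a lower number a stronger inhibitor), compound 1 `CCc1cccc(CC)c1NC1=NCCC2(CCCCC2)S1` gives 7900 nM, compound 3 `CCc1ccc(NC2=NCCC3(CCCCC3)S2)cc1` gives 11700 nM, and compound 2 `Clc1ccc(NC2=NCCC3(CCCCC3)S2)cc1` gives 35500 nM, the highest number of the three. Among the compounds with values here, the step of a 3.0-fold lower number from compound 2 to compound 3 (0.48 log units; beyond the scatter) is the one measured change that bears on compound 4 `CC(C)c1ccc(NC2=NCCC3(CCCCC3)S2)cc1`, whose difference from compound 2 is isopropyl in place of chloro on an aromatic carbon. Since ethyl in place of chloro lowered the number beyond the scatter, isopropyl in place of chloro is expected to do much the same, a step of about a 3.7-fold lower number from compound 2 to compound 4 (0.57 log units; beyond the scatter). Compound 4 is therefore estimated at 9500 nM in this assay, within a range from 4000 nM to 25000 nM.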

Compound 4, half-maximal inhibitory concentration: 6200 nM
The estimate for compound 4 lay 1.5-fold (0.19 log units) above the measured number, and the stated range covers the measured number.
By their numbers in this assay, from the lowest: compounds 4, 1 and 3 (each within the scatter of the next); then compound 2.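

In this assay the change of isopropyl in place of chloro gives a 5.7-fold lower number from compound 2 to compound 4 (0.76 log units; beyond the scatter) and so shows that a second alkyl group at this position also parts clearly from chloro. The added methyl on the saturated chain carbon gives only a 1.9-fold lower number from compound 3 to compound 4 (0.28 log units; within the scatter) and leaves isopropyl and ethyl indistinguishable here. Nothing available explains either step.

On these data alone, whether the lower number extends to a longer chain, a tert-butyl group or a cyclohexyl ring remains open. So does whether a methoxy group or an amine at this position would behave like the alkyl groups or like chloro.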